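Notes on the aryl terminus: amino to tert-butoxycarbonylamino

The source may report more compounds than this note shows. Statements on the series, on what has been measured and on what is new or still open speak of the compounds shown alone.

Compound 1 `O=C(O)c1ccc(CCCCCCC(=O)c2ncc(-c3ccccn3)o2)cc1` carries a carboxy group on the terminal aromatic ring; in an assay for inhibition of Fatty-acid amide hydrolase 1 (Rattus norvegicus) (a higher number here means a weaker inhibitor, a lower number a stronger inhibitor), compound 1 reaches only a limit of the assay, > 600 nM, which is a limit and not a number (the limit of > 600 nM in this assay, at which 1 of the 3 values shown sits). Compound 2 `COc1ccc(CCCCCCC(=O)c2ncc(-c3ccccn3)o2)cc1` gives 6.2 nM in this assay, and compound 3 `Nc1ccc(CCCCCCC(=O)c2ncc(-c3ccccn3)o2)cc1` gives 3 nM. Both exchanges on the aromatic carbon are large: an at least 96-fold lower number from compound 1 to compound 2 (1.98 log units; beyond the scatter) and an at least 200-fold lower number from compound 1 to compound 3 (2.30 log units; beyond the scatter). Between methoxy and amino the step is modest but beyond the scatter: a 2.1-fold lower number from compound 2 to compound 3 (0.32 log units; beyond the scatter). Compound 3 thus holds the lowest of the two measured numbers, with compound 2 nearest.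

Compound 4 `CC(C)(C)OC(=O)Nc1ccc(CCCCCCC(=O)c2ncc(-c3ccccn3)o2)cc1` differs from compound 3 by tert-butoxycarbonyl in place of hydrogen on a nitrogen on an aromatic ring. Going by the values given here, no measured step alters the nitrogen itself; the nearest precedents are the exchanges on the aromatic carbon, where carboxy sits far beyond methoxy and amino while those two lie close together. The group entering compound 4 carries no net charge, like methoxy and amino, so a modest rise in the number is expected, a 2.7-fold higher number from compound 3 to compound 4 (0.43 log units; beyond the scatter), and no return to a limit. Compound 4 is estimated at 8 nM, within 2.5 nM to 30 nM.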

Compound 4, inhibition constant: 5.6 nM
The estimate for compound 4 lay 1.4-fold (0.15 log units) above the measured number; the measured number falls inside the stated range.
By their numbers in this assay, from the lowest: compounds 3, 4 and 2 (each within the scatter of the next, the first and the last beyond it). At a limit, above all of these: compound 1.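

In this assay, tert-butoxycarbonyl, with 7 heavy atoms and no net charge, replaces a hydrogen atom on the nitrogen, and the step stays small: a 1.9-fold higher number from compound 3 to compound 4 (0.27 log units; within the scatter). Compound 4 also cannot be told apart from the methoxy compound, with a 1.1-fold lower number from compound 2 to compound 4 (0.04 log units; within the scatter), so this much larger group on the terminal ring gives a number within the scatter of both compound 2 and compound 3, even though those two lie beyond the scatter of each other. The gap to the carboxy compound remains large, at an at least 100-fold lower number from compound 1 to compound 4 (2.02 log units; beyond the scatter), but this step starts from compound 1, which stands at a limit and not at a number: the limit of > 600 nM in this assay, at which 1 of the 4 values shown sits.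

Going by these compounds, it remains open whether a smaller acyl group such as acetyl on the same nitrogen, or a dimethylamino group in place of amino, would give a number in the same range as compounds 2, 3 and 4. On these data alone, it is equally open whether a methyl ester or a primary carboxamide in place of carboxy would stay at the limit of compound 1 or join those three.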